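This account rests on a few compounds, and the source may have more. Where it says the series, first, only, none or still open, it means among the compounds named here.

Measured in an ADME assay on C8166 cells (Homo sapiens) for cytotoxicity, read by MTT assay, with a stated time of 72 h; on this read-out higher numbers stand for lower toxicity in this test and lower numbers for higher toxicity in this test:
- Compound 1 `Oc1cc2c(cc1O)C(c1ccco1)NCC2`: > 865000 nM (a limit)
- Compound 2 `Oc1cc2c(cc1O)C(c1ccc(Br)cc1)NCC2`: > 625000 nM (a limit)
- Compound 3 `COc1cc2c(cc1OC)C(c1ccc(C(F)(F)F)cc1)NCC2`: 30900 nM

Compound 2 stands at > 625000 nM, which is a limit and not a number. Compound 1 also gives only a limit, so compound 3 alone has a true number. Compound 4 `Cc1ccc(C2NCCc3cc(O)c(O)cc32)cc1` differs from compound 2 as follows: methyl in place of bromo on an aromatic carbon. This puts methyl in place of bromo on an aromatic carbon. Within the data shown here, no measured step covers this change, so no shift beyond the usual scatter is expected in this assay, and a limit is again the likely result. The estimated step of an at least 1.0-fold lower number from compound 2 to compound 4 (0.01 log units; that floor lies within the scatter) is expected to stay within the scatter. For compound 4 the estimate is 600000 nM, with an expected range of 150000 nM to 800000 nM.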

Compound 4, half-maximal cytotoxic concentration: > 784000 nM
Compound 4 was reported as a limit (the forecaster's own chance of this, stated with the estimate: 65%); at least 1.3-fold (0.11 log units) between middle value and limit.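

Compound 2 gives > 625000 nM, a limit. Compound 4 gives > 784000 nM, also a limit. The step between compound 2 and compound 4 therefore cannot be read. The compounds shown leave open whether methyl in place of bromo shifts the read-out in this assay at all.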